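Para chloro within the weaker diastereomer pairing

A few compounds are considered here, and "the series" means these few. Any claim that something is new, unique, unknown or untested is made for them only; others in the source may bear on it.

Compound 1 `CC[C@H](NC(C)=O)c1cc(Cl)ccc1C1CCN(C(=O)[C@H]2CN(C(C)(C)C)C[C@@H]2c2ccc(F)cc2F)CC1` gives the highest number of the three measured compounds in a functional assay on CHO cells for agonist activity at Melanocortin receptor 4 (Homo sapiens), read by cAMP accumulation (a higher number here means that more compound is needed for the effect, a lower number that less compound is needed), at 565 nM. Compound 2 `CC[C@H](NC(C)=O)c1cc(Cl)ccc1C1CCN(C(=O)[C@@H]2CN(C(C)(C)C)C[C@H]2c2ccc(F)cc2F)CC1` gives 17.9 nM, the step of a 32-fold lower number from compound 1 to compound 2 (1.50 log units; beyond the scatter) resting on (the fact that compounds 1 and 2 differ only in the configuration as drawn). Compound 3 `CC[C@H](NC(C)=O)c1cc(Cl)ccc1C1CCN(C(=O)[C@@H]2CN(C(C)(C)C)C[C@H]2c2ccc(Cl)cc2Cl)CC1` gives 156 nM, the step being an 8.7-fold higher number from compound 2 to compound 3 (0.94 log units; beyond the scatter). Compound 4 `CC[C@H](NC(C)=O)c1cc(Cl)ccc1C1CCN(C(=O)[C@H]2CN(C(C)(C)C)C[C@@H]2c2ccc(Cl)cc2F)CC1` differs from compound 1 by chloro in place of fluoro on an aromatic carbon. Among the compounds with values here, only the step from compound 2 to compound 3 bears on this change; it was modest and covered a broader exchange of halogens than that in compound 4, so a smaller loss is expected here, though probably still beyond the scatter. Compound 4 is therefore estimated at 1500 nM, within 500 nM to 5000 nM. The expected step is a 2.7-fold higher number from compound 1 to compound 4 (0.42 log units; beyond the scatter).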

Compound 4, half-maximal effective concentration: 111 nM
For compound 4 the middle estimate is 14-fold (1.13 log units) above the measured one; the measured number lies below the stated range.
By their numbers in this assay, from the lowest: compound 2; then compounds 4 and 3 (each within the scatter of the next); then compound 1.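

The step of a 5.1-fold lower number from compound 1 to compound 4 (0.71 log units; beyond the scatter) in this assay comes from chloro in place of fluoro para to a large group, with the fluoro group meta to it kept. Its direction is opposite to that of an 8.7-fold higher number from compound 2 to compound 3 (0.94 log units; beyond the scatter) in the other configuration, where a second halogen also changes. A halogen result therefore cannot be carried from one configuration to the other, and configuration alone already moves the number: the fact that compounds 1 and 2 differ only in the configuration as drawn

Within the data shown here, open is whether the single chloro exchange lowers the number in the configuration of compound 2. Also open, on these data alone, is how a methoxy group or a nitrile would read at this position.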